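This account rests on a few compounds, and the source may have more. Where it says the series, first, only, none or still open, it means among the compounds named here.

In a functional assay on AGS cells (Homo sapiens) for inhibition, read by reporter gene assay (a lower number here means a stronger inhibitor, a higher number a weaker inhibitor), compound 2 `NC(=O)c1cccc(NC(=O)COc2ccccc2)c1` gives > 30000 nM, which is a limit of the assay and not a number. Compound 1 `Cc1ccc(OCC(=O)Nc2cccc(C(=O)O)c2)cc1` gives > 30000 nM, which is likewise only a limit. Compound 3 `Cc1ccc(OCC(=O)Nc2cccc(C(N)=O)c2)cc1` differs from compound 2 by a methyl in place of hydrogen on an aromatic carbon, para to a large group: methyl in place of hydrogen on an aromatic carbon. Going by the values given here, no pair of measured compounds shows this change alone, so at most a small shift toward stronger inhibition in this assay is expected, perhaps none beyond the usual scatter. The expected step is an at least 1.5-fold lower number from compound 2 to compound 3 (0.17 log units; that floor lies within the scatter). The estimated value for compound 3 is 20000 nM, with an expected range of 6000 nM to 60000 nM.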

Compound 3, half-maximal inhibitory concentration: > 30000 nM
Compound 3 was reported as a limit; the forecaster's own chance of this, stated with the estimate: 60%; at least 1.5-fold (0.17 log units) between middle value and limit.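

Going by these compounds alone, compound 1, compound 2 and compound 3 are all reported only as limits in this assay, so no step among them can be read: the limit of > 30000 nM in this assay, at which 3 of the 3 values shown sit.

From the compounds shown here alone, whether methyl in place of hydrogen, or amino in place of hydroxy, changes inhibition at all stays open.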